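A Lactam Oxygen Enters the Piperidine of Compound 3

The compounds below may be only part of what the source reports. "The series", "measured", "known", "first", "only" and "open" are said of these compounds alone.

Three measured compounds share one core and differ only in the amide at its edge. Compound 1 `CNC(=O)c1ccncc1Nc1cc(-c2ccc3ccn(C)c3c2)c2nccnc2c1` carries a methyl on the amide nitrogen, and in an assay on lysate for inhibition of 6-phosphofructo-2-kinase/fructose-2,6-bisphosphatase 3 (Homo sapiens), with stated times of 0.5 min and 45 min (a lower number here means a stronger inhibitor, a higher number a weaker inhibitor), compound 1 gives 7020 nM. Compound 2 `CN(C)C(=O)c1ccncc1Nc1cc(-c2ccc3ccn(C)c3c2)c2nccnc2c1` carries two methyls there. In this assay compound 2 reaches only a limit of the measurement, > 100000 nM. For the measured compounds named here, compound 3 `CN1CCC(NC(=O)c2ccncc2Nc2cc(-c3ccc4ccn(C)c4c3)c3nccnc3c2)CC1` carries a 1-methylpiperidin-4-yl on that nitrogen, and in this assay compound 3 gives 19500 nM, the highest of the two numbers known; the change is a 2.8-fold higher number from compound 1 to compound 3 (0.44 log units; beyond the scatter), while an at least 5.1-fold lower number from compound 2 to compound 3 (0.70 log units; beyond the scatter) runs from a limit (the limit of > 100000 nM in this assay, at which 1 of the 3 values shown sits). Compound 4 `CN1CCC(NC(=O)c2ccncc2Nc2cc(-c3ccc4ccn(C)c4c3)c3nccnc3c2)CC1=O` is the next member: 1-methyl-2-oxopiperidin-4-yl in place of 1-methylpiperidin-4-yl on an amide-type nitrogen. Going by the values given here, no measured step puts an oxygen into this ring, so the measured steps bear on it only loosely: a 2.8-fold higher number from compound 1 to compound 3 (0.44 log units; beyond the scatter) shows that enlarging the group on the amide nitrogen weakened inhibition modestly, and an at least 14-fold higher number from compound 1 to compound 2 (1.15 log units; beyond the scatter) shows that removing the amide hydrogen weakened it heavily, but compound 4 keeps that hydrogen and keeps the ring. Compound 4 is therefore expected to remain close to compound 3, with a 1.1-fold higher number from compound 3 to compound 4 (0.05 log units; within the scatter) as the expected step. In this assay compound 4 is estimated at 22000 nM, expected between 7000 nM and 70000 nM.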

Compound 4, half-maximal inhibitory concentration: 48800 nM
Compound 4: middle estimate off by 2.2-fold (0.35 log units), on the low side; measured number inside the range.
By their numbers in this assay, from the lowest: compound 1; then compound 3; then compound 4. At a limit, above all of these: compound 2.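

In this assay, this position responds to a change inside the ring itself: 1-methyl-2-oxopiperidin-4-yl in place of 1-methylpiperidin-4-yl on the amide-type nitrogen gives a 2.5-fold higher number from compound 3 to compound 4 (0.40 log units; beyond the scatter). For the compounds shown here, until now, every measured change had replaced the whole group on that nitrogen or added a second group there, so this is the first sign that a single carbonyl in an otherwise retained ring can weaken inhibition beyond the scatter. Compared with the plain methyl, the new group gives a 7.0-fold higher number from compound 1 to compound 4 (0.84 log units; beyond the scatter), which shows that keeping the amide hydrogen does not by itself hold inhibition near the level of compound 1, while an at least 2.0-fold lower number from compound 2 to compound 4 (0.31 log units; beyond the scatter) starts from a limit rather than a true number: the limit of > 100000 nM in this assay, at which 1 of the 4 values shown sits.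

The compounds shown do not tell whether the loss comes from the carbonyl as such or from where it sits in the ring, nor why the number rises at all. They also leave open how a hydroxyl group or a fluorine on the piperidine ring, or a smaller group such as ethyl or cyclopropyl on the amide nitrogen, would compare with the methyl of compound 1.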